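Dichloro to monochloro on the fused core, ortho-benzyl series

A few compounds are considered here, and "the series" means these few. Any claim that something is new, unique, unknown or untested is made for them only; others in the source may bear on it.

Measured so far:
compound 1 `ClCc1ccc(Cn2cnc3c(Cl)ncnc32)cc1`: 5490 nM
compound 2 `ClCc1ccccc1Cn1cnc2c(Cl)nc(Cl)nc21`: 490 nM

Two compounds have numbers in a functional assay on RXF 393 cells (Homo sapiens) for cytotoxicity, read by sulforhodamine B assay, with a stated time of 48 h; a lower number here means a stronger inhibitor of growth, a higher number a weaker inhibitor of growth. Compound 1 gives 5490 nM. Compound 2 gives the lower of the two numbers, 490 nM, and the gap to compound 1 lies beyond the scatter; the two compounds differ in more than one place, so no single change can be read from that gap.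

Compound 3 `ClCc1ccccc1Cn1cnc2c(Cl)ncnc21` is the next member and has no number yet in this assay. Relative to compound 2 the change is hydrogen in place of chloro on an aromatic carbon. Compound 1 also carries a single chloro on its core, yet its benzyl group is arranged differently from that of compound 3, so compound 1 gives only a loose reference point.

Among the compounds with values here, with no one-place step measured, the expectation rests on the standing of compound 2 and the weaker compound 1. The step from compound 2 to compound 3 is expected to be a loss in this assay, of moderate size, a 3.1-fold higher number from compound 2 to compound 3 (0.49 log units; beyond the scatter). Compound 3 is expected to give 1500 nM, with a range from 500 nM to 5000 nM.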

Compound 3, concentration for total growth inhibition: 2340 nM
The estimate for compound 3 lay 1.6-fold (0.19 log units) below the measured number, and the stated range covers the measured number.
By their numbers in this assay, from the lowest: compound 2; then compound 3; then compound 1.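

In this assay, within the data shown here, removing the chloro from the aromatic carbon between two ring nitrogen atoms gives the first one-place reading: a 4.8-fold higher number from compound 2 to compound 3 (0.68 log units; beyond the scatter), beyond the scatter, with the other chloro and the benzyl group unchanged. Compounds 1 and 2 differ in more than one place and could not isolate this carbon, whereas the present pair shows that, with this benzyl arrangement, chloro at this position goes with the stronger growth inhibition and hydrogen with the weaker. No available data bear on the reason for this loss.

The compounds shown leave open whether the preference is specific to chloro or would extend to another group on the same carbon, such as fluoro, methoxy or an amine. Among these compounds, they also leave open whether the step carries over to the benzyl arrangement of compound 1, which has no partner here bearing chloro at this carbon, so no step to or from compound 1 can be read.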